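Returning the Amide Nitrogen to a Ring, Now Phenyl-Bearing

The source may report more compounds than this note shows. Statements on the series, on what has been measured and on what is new or still open speak of the compounds shown alone.

Of the compounds shown here, two have numbers so far. In a functional assay on B16-F10 cells (Mus musculus) for inhibition, read by MTT assay, with a stated time of 48 h (a lower number here means a stronger inhibitor, a higher number a weaker inhibitor), compound 1 `COc1ccc(/C=C/c2cc(OC)cc(OC)c2/C=C/C(=O)N2CCCCC2)cc1` gives 9750 nM. Compound 2 `COc1ccc(/C=C/c2cc(OC)cc(OC)c2/C=C/C(=O)NC(C)C)cc1`, the open-chain amide, gives 4020 nM in this assay and so holds the lowest of the two numbers. Among the measured compounds shown here, the single known step is a 2.4-fold lower number from compound 1 to compound 2 (0.38 log units; beyond the scatter), a modest gain for the amide without a ring on its nitrogen.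

Compound 3 `COc1ccc(/C=C/c2cc(OC)cc(OC)c2/C=C/C(=O)N2CCC(c3ccccc3)CC2)cc1` differs from compound 2 at one place: 4-phenylpiperidin-1-yl in place of isopropylamino on a carbonyl carbon. For the measured compounds named here, the one step that bears on this change is a 2.4-fold lower number from compound 1 to compound 2 (0.38 log units; beyond the scatter), and compound 3 runs it backwards, putting a ring on the amide nitrogen again while adding a phenyl group whose effect is not known from any measured pair. Since compound 1 with its ring on the amide nitrogen gave 9750 nM, the expected step is a 2.0-fold higher number from compound 2 to compound 3 (0.30 log units; within the scatter). Compound 3 is therefore expected to give about 8000 nM, with a range of 3000 nM to 25000 nM.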

Compound 3, half-maximal inhibitory concentration: 9180 nM
Compound 3: middle estimate off by 1.1-fold (0.06 log units), on the low side; measured number inside the range.
By their numbers in this assay, from the lowest: compound 2; then compounds 3 and 1 (each within the scatter of the next).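

In this assay, phenyl in place of hydrogen on a saturated ring carbon gives a 1.1-fold lower number from compound 1 to compound 3 (0.03 log units; within the scatter), so this added ring makes no difference that can be told apart from the scatter. The change from isopropylamino to 4-phenylpiperidin-1-yl gives a 2.3-fold higher number from compound 2 to compound 3 (0.36 log units; beyond the scatter), which leaves compound 2, the only one of the three with an amide hydrogen, with a lower number than either ring amide, even with the larger group on the ring. Nothing measured here explains this pattern.

A dimethylamino group on the carbonyl carbon, with no ring and no amide hydrogen, would help separate those two differences, but it is not among these compounds. Also open, from the compounds shown here alone, is whether a smaller ring, such as pyrrolidin-1-yl, or a longer open chain, such as n-butylamino, would give a lower number than compound 2.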